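The compounds below may be only part of what the source reports. "The series", "measured", "known", "first", "only" and "open" are said of these compounds alone.

Measured so far in a functional assay on HCT-15 cells (Homo sapiens) for cytotoxicity, read by CCK-8 assay and cell counting, with a stated time of 2 days (on this read-out higher numbers stand for weaker inhibition and lower numbers for stronger inhibition), are:
compound 1 `Oc1ccc(-c2cc(-c3cccc(Cl)c3)nc(-c3ccccn3)c2)cc1` (28200 nM)
compound 2 `Oc1ccc(-c2cc(-c3ccc(Cl)cc3)nc(-c3ccsc3)c2)cc1` (6240 nM)
compound 3 `Oc1ccc(-c2cc(-c3ccsc3)nc(-c3ccccc3Cl)c2)cc1` (5830 nM)

Compound 3 (5830 nM) lies within the scatter of compound 2 (6240 nM), and both stand clear of the higher number of compound 1 (28200 nM). The next compound, compound 4 `Oc1ccc(-c2cc(-c3ccsc3)nc(-c3cccc(Cl)c3)c2)cc1`, carries 3-chlorophenyl in place of 2-chlorophenyl on an aromatic carbon. The closest measured step is the exchange of 4-chlorophenyl for 2-chlorophenyl (a 1.1-fold lower number from compound 2 to compound 3 (0.03 log units; within the scatter)), and it stays within the scatter. Compound 4 differs elsewhere from compound 1 (28200 nM), which also carries 3-chlorophenyl, so that value only leaves some room upward. No step beyond the scatter is therefore expected in this assay and no direction is favoured. The expected change is small (a 1.1-fold higher number from compound 3 to compound 4 (0.05 log units; within the scatter)). For compound 4 the expected value is 6500 nM (estimated range 3200 nM to 13500 nM).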

Compound 4, half-maximal inhibitory concentration: 5760 nM
Estimate against measurement, compound 4: 1.1-fold (0.05 log units) above, within the range that was stated.
By their numbers in this assay, from the lowest: compounds 4, 3 and 2 (each within the scatter of the next); then compound 1.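

Moving the chlorine within the chlorophenyl group at this position registers in none of the steps in this assay: there is a 1.0-fold lower number from compound 3 to compound 4 (0.01 log units; within the scatter), and there is a 1.1-fold lower number from compound 2 to compound 4 (0.03 log units; within the scatter), so the 2-chlorophenyl, 3-chlorophenyl and 4-chlorophenyl compounds stand level. For the compounds shown here, compound 4 also provides the first comparison with compound 1 that differs in one place, with 3-chlorophenyl kept and thiophen-3-yl in place of pyridin-2-yl: there is a 4.9-fold lower number from compound 1 to compound 4 (0.69 log units; beyond the scatter), so this single pair ties the higher number of compound 1 to that exchange rather than to the chlorine's position. Nothing available explains either the flat chlorine series or this step.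

Going by these compounds, it remains open whether pyridin-2-yl gives a similar step alongside 2-chlorophenyl or 4-chlorophenyl. On these data alone, it is also open whether an amine or a carboxylic acid in place of the chlorine would leave the number unchanged.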